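Swapping the naphthalene arm for a thiophene ring

The source may report more compounds than this note shows. Statements on the series, on what has been measured and on what is new or still open speak of the compounds shown alone.

Measured so far:
compound 1 `COc1ccc(-c2cn3ccnc3c(-c3ccc4ncn(C5CCCCC5)c4c3)n2)cc1` — 78.8%
compound 2 `c1ccc2c(-c3cn4ccnc4c(-c4ccc5ncn(C6CCCCC6)c5c4)n3)cccc2c1` — 4.46%

In a functional assay on HCT-15 cells (Homo sapiens) for inhibition, read by sulforhodamine B assay, with a stated time of 48 h, tested at 10 uM (a lower number here means less inhibition, a higher number more inhibition at the concentration tested (going by the name of the read-out)), compound 1 reaches 78.8%, while compound 2 gives 4.46%. Compound 2 therefore stands lowest of the two numbers, and the step of a number 74.3 percentage points lower from compound 1 to compound 2 (beyond the scatter) is far beyond the scatter. The two compounds share one core and differ only in the group on an aromatic carbon: 4-methoxyphenyl in compound 1, naphthalen-1-yl in compound 2.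

Compound 3 `c1cn2cc(-c3ccsc3)nc(-c3ccc4ncn(C5CCCCC5)c4c3)c2n1` has not been tested in this assay. It differs from compound 2 in one place: thiophen-3-yl in place of naphthalen-1-yl on an aromatic carbon. Going by the values given here, the only measured step that bears on this change is the one from compound 1 to compound 2, where replacing one six-membered aromatic ring carrying an acceptor with two six-membered aromatic rings of carbon only cost a large amount of inhibition. Thiophen-3-yl is again a single ring with one acceptor, so a return toward higher inhibition is expected, but no measured compound carries a five-membered ring here, so the expected size is uncertain. Compound 3 is estimated at 50% (range 15% to 85%), meaning an expected step of a number 45.5 percentage points higher from compound 2 to compound 3 (beyond the scatter).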

Compound 3, a percentage reported as inhibition, at one concentration (the size of the read-out at that concentration, not a potency): 1.37%
Estimate against measurement, compound 3: 48.6 percentage points above; the measured number lies below the stated range.
By their numbers in this assay, from the lowest: compounds 3 and 2 (each within the scatter of the next); then compound 1.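

In this assay the thiophen-3-yl group gives a number 3.1 percentage points lower from compound 2 to compound 3 (within the scatter) when it replaces naphthalen-1-yl, so a group of 5 heavy atoms with one five-membered aromatic ring and 1 hydrogen-bond acceptor reads the same as one of 10 heavy atoms with 2 six-membered aromatic rings of carbon only. Set against the 4-methoxyphenyl group, the same thiophen-3-yl group gives a number 77.4 percentage points lower from compound 1 to compound 3 (beyond the scatter) and so sits with naphthalen-1-yl at the low end: among these three compounds, neither a single aromatic ring nor the presence of an acceptor on the group goes with high inhibition, and only 4-methoxyphenyl does. Nothing measured here accounts for why this one group stands apart from the other two.

Still open, from the compounds shown here alone, is whether the methoxy group itself matters or the six-membered ring that carries it, a question that a plain phenyl, a 4-hydroxyphenyl or a 4-aminophenyl group at this position would address. These readings also come from a single concentration in one cell line, so they give no potency for any of the three compounds.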